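Removing the Ethoxy Group from the Weakest Compound

The source may hold more compounds than are shown below. What is called first, only, known or untested is meant among the compounds shown, and "the series" means these compounds.

Compound 1 `CCOc1ccc(-c2nn3cc(-c4cccc(N)c4)nc3s2)cc1` holds the highest number of the three measured compounds: in a functional assay on L1210 cells (Mus musculus) for inhibition, read by cell counting, with a stated time of 2 days (a lower number here means a stronger inhibitor, a higher number a weaker inhibitor), compound 1 gives 155000 nM. Compound 2 `C=C(Br)C(=O)Nc1cccc(-c2cn3nc(Cc4ccccc4)sc3n2)c1` gives 3000 nM, and compound 3 `C=C(Br)C(=O)Nc1cccc(-c2cn3nc(-c4ccc(OCC)cc4)sc3n2)c1` gives 790 nM, so compound 1 stands well behind both and is the weakest inhibitor of the set. For the measured compounds named here, two measured steps lead into compound 3 and show what has moved the numbers so far: a 200-fold lower number from compound 1 to compound 3 (2.29 log units; beyond the scatter), and a 3.8-fold lower number from compound 2 to compound 3 (0.58 log units; beyond the scatter). The first of these is the large one; the second, which reshapes the group on the far side of the shared core, is only modest.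

Compound 4 `Nc1cccc(-c2cn3nc(-c4ccccc4)sc3n2)c1` keeps the free amine of compound 1 and differs from it in a single spot: hydrogen in place of ethoxy on an aromatic carbon. Going by the values given here, no measured pair isolates exactly this change. The closest guidance is the modest size of the step from compound 2 to compound 3, because a 3.8-fold lower number from compound 2 to compound 3 (0.58 log units; beyond the scatter) shows that changing the group on that side of the core shifts the number by far less than the acrylamide did. A small step is therefore expected, likely toward a weaker compound, and it may well stay within the usual scatter. Compound 4 is estimated at 220000 nM, with a range from 70000 nM to 700000 nM, which corresponds to an expected 1.4-fold higher number from compound 1 to compound 4 (0.15 log units; within the scatter).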

Compound 4, half-maximal inhibitory concentration: 32000 nM
For compound 4 the middle estimate is 6.9-fold (0.84 log units) above the measured one, outside the stated range (below it).
By their numbers in this assay, from the lowest: compound 3; then compound 2; then compound 4; then compound 1.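

Taking the ethoxy group off the six-membered aromatic ring, para to a large group, gives a 4.8-fold lower number from compound 1 to compound 4 (0.69 log units; beyond the scatter) in this assay, so with the free amine in place this ethoxy is not needed for inhibition and the compound does better without it. For the compounds shown here, this is the first step that changes this one position alone, since the earlier step on that side of the shared core swapped a whole benzyl group for a 4-ethoxyphenyl group and could not separate the ethoxy from the rest of that change. The step is clearly real, yet it remains much smaller than the change at the amine, a 200-fold lower number from compound 1 to compound 3 (2.29 log units; beyond the scatter), and nothing available here explains why removing the ethoxy lowers the number.

As far as these compounds go, it remains open whether removing the ethoxy group would also lower the number in a compound that carries the (1-bromoethenyl)carbonyl group on its nitrogen. From the compounds shown here alone, it is also open how a methoxy group, a hydroxyl group or a longer chain such as propoxy would behave at this position, and so whether hydrogen is the best choice there or only better than ethoxy.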